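Chlorinated, methyl-shifted anilide on the shared core

The source may hold more compounds than are shown below. What is called first, only, known or untested is meant among the compounds shown, and "the series" means these compounds.

Measured so far:
compound 1 `Cc1cc(NC(=O)CN2CCC(c3cccc[n+]3[O-])CC2)ccc1F`: 18 nM
compound 2 `Cc1cccc(NC(=O)CN2CCC(c3cccc(O)c3)CC2)c1`: 8 nM

Within the data shown here, in a functional assay on HEK293 cells for agonist activity at D(4) dopamine receptor (Homo sapiens), read by FLIPR (on this read-out higher numbers stand for an effect only at larger amounts of compound and lower numbers for an effect already at smaller amounts), compound 1 gives 18 nM, the highest of the two numbers so far. Its nearest neighbour is compound 2, which in this assay gives 8 nM; that gap is beyond the scatter, but compound 2 differs from compound 1 in more than one place, so no single step can be read from the pair. Compound 3 `Cc1ccc(Cl)cc1NC(=O)CN1CCC(c2cccc[n+]2[O-])CC1` keeps the core of compound 1 and changes only the aryl group on the amide nitrogen: 5-chloro-2-methylphenyl in place of 4-fluoro-3-methylphenyl on an amide-type nitrogen. Among the measured compounds shown here, no measured pair isolates this kind of exchange, so the expectation for compound 3 rests on compound 1 alone and on the closeness of its value 18 nM to that of compound 2. The step of a 1.4-fold higher number from compound 1 to compound 3 (0.14 log units; within the scatter) is expected to be small, likely within the scatter or slightly upward. For compound 3 the estimate is 25 nM, in the range 8 nM to 80 nM.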

Compound 3, half-maximal effective concentration: 126 nM
Estimate against measurement, compound 3: 5.0-fold (0.70 log units) below; the whole stated range lies below it.
By their numbers in this assay, from the lowest: compound 2; then compound 1; then compound 3.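

In this assay, among these compounds, putting 5-chloro-2-methylphenyl in place of 4-fluoro-3-methylphenyl on the amide-type nitrogen gives a 7.0-fold higher number from compound 1 to compound 3 (0.85 log units; beyond the scatter), the first single-place step in this set. The two aryl groups have the same counts of heavy atoms, hydrogen-bond donors and hydrogen-bond acceptors, and neither carries a net charge, so a step beyond the scatter appears here with none of these counts changing. Nothing measured here accounts for the size of this step.

The exchange swaps fluorine for chlorine and alters the substitution pattern on the ring at once, so the compounds shown cannot separate the contribution of the halogen from that of its placement or the placement of the methyl group. They also leave open how this position would respond to a nitrile or a methoxy group in place of the chlorine.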